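The source may hold more compounds than are shown below. What is called first, only, known or untested is meant among the compounds shown, and "the series" means these compounds.

Compound 2 `Clc1ccccc1/C=N/c1sc2c(c1-c1nc3ccccc3s1)CCCC2` is the second of two close relatives measured in an ADME assay on HepG2 cells (Homo sapiens) for cytotoxicity, read by MTT assay, with a stated time of 72 h; on this read-out lower numbers stand for higher toxicity in this test and higher numbers for lower toxicity in this test. Its partner, compound 1 `Fc1ccccc1/C=N/c1sc2c(c1-c1nc3ccccc3s1)CCCC2`, gives 398 ug/mL in this assay, and compound 2 gives 370 ug/mL. Among the compounds with values here, the single measured step, a 1.1-fold lower number from compound 1 to compound 2 (0.03 log units; within the scatter), is the exchange of one halogen for another on the aromatic ring, and it leaves the read-out essentially unchanged. Compound 2 thus holds the lower of the two numbers, with compound 1 a short way up and inside the scatter, so neither can be called more or less toxic than the other.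

The next compound, compound 3 `C(=C/c1ccccc1)\C=N\c1sc2c(c1-c1nc3ccccc3s1)CCCC2`, departs from compound 2 in one place: 2-phenylethenyl in place of 2-chlorophenyl on a carbon with a double bond to nitrogen. Within the data shown here, no measured step covers a change of this kind; the halogen swap from compound 1 to compound 2 speaks only to the ring that is now removed, so it offers no guide to the direction of this step. The expectation for compound 3 in this assay is therefore a value near that of compound 2, with the step of a 1.1-fold lower number from compound 2 to compound 3 (0.02 log units; within the scatter) expected to stay within the scatter, giving an estimate of 350 ug/mL with a range from 150 ug/mL to 800 ug/mL.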

Compound 3, half-maximal cytotoxic concentration: 467 ug/mL
The estimate for compound 3 lay 1.3-fold (0.13 log units) below the measured number; measured number inside the range.
By their numbers in this assay, from the lowest: compounds 2, 1 and 3 (each within the scatter of the next).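

Placing 2-phenylethenyl on the carbon with a double bond to nitrogen gives a 1.3-fold higher number from compound 2 to compound 3 (0.10 log units; within the scatter) and, set against the fluorinated partner, a 1.2-fold higher number from compound 1 to compound 3 (0.07 log units; within the scatter) in this assay. The earlier pair spoke only to one halogen exchanged for another on the aromatic ring, whereas these steps show that the read-out stays within the scatter even when the whole 2-chlorophenyl group gives way to a group with no halogen and with a double bond outside aromatic rings, so compound 1, compound 2 and compound 3 cannot be separated from one another. No evidence is available that bears on this result.

From the compounds shown here alone, both groups compared at this place carry a six-membered aromatic ring of carbon only and no hydrogen-bond donors or acceptors, so it stays open whether an amine, a carboxylic acid or a longer chain there would give a number beyond the scatter. Going by these compounds, how a change on the shared core itself would read in this assay also remains open.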